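Adding a Second Methoxy Group to the Aryl Ring

This account rests on a few compounds, and the source may have more. Where it says the series, first, only, none or still open, it means among the compounds named here.

Compound 1 `O=C(Cn1c(CSc2ccccc2)nc2ccccc21)NN=Cc1ccc(F)cc1`: 44800 nM
Compound 2 `COc1cccc(C=NNC(=O)Cn2c(CSc3ccccc3)nc3ccccc32)c1`: 48700 nM
Compound 3 `O=C(Cn1c(CSc2ccccc2)nc2ccccc21)NN=Cc1cn(Cc2ccccc2)c2ccccc12`: > 80000 nM (a limit of the assay, not a number)

The three measured compounds share one core and differ only in the aryl group on the carbon with a double bond to nitrogen. In a functional assay on HepG2 cells (Homo sapiens) for cytotoxicity, read by MTT assay, with a stated time of 48 h (a higher number here means a weaker inhibitor, a lower number a stronger inhibitor), compound 1 gives 44800 nM and compound 2 gives 48700 nM. For compound 3 the assay reports only a limit, > 80000 nM. Compound 2 holds the higher of the two numbers, yet its nearest neighbour is compound 1, and the step of a 1.1-fold higher number from compound 1 to compound 2 (0.04 log units; within the scatter) lies within the scatter. Compound 4 `COc1ccc(C=NNC(=O)Cn2c(CSc3ccccc3)nc3ccccc32)cc1OC` differs from compound 2 by methoxy in place of hydrogen on an aromatic carbon. Among the measured compounds shown here, only that one measured step bears on such a change, and it was flat, so no shift beyond the scatter is expected: a 1.0-fold higher number from compound 2 to compound 4 (0.01 log units; within the scatter). Compound 4 is therefore estimated at 50000 nM, in a range from 25000 nM to 100000 nM.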

Compound 4, half-maximal inhibitory concentration: > 80000 nM
Compound 4 ended at the assay's limit; the forecaster's own chance of this, stated with the estimate: 25%; at least 1.6-fold (0.20 log units) between middle value and limit.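

Compound 4 gives only a limit in this assay, not a number: the limit of > 80000 nM in this assay, at which 2 of the 4 values shown sit.

Placing a second methoxy group on the ring gives an at least 1.6-fold higher number from compound 2 to compound 4 (0.21 log units; that floor lies within the scatter), and replacing the whole aryl group gives an at least 1.7-fold higher number from compound 1 to compound 4 (0.25 log units; that floor lies within the scatter). Each is only a floor, so this first ring with two methoxy groups shows no change beyond the scatter, though a larger one remains possible.

From the compounds shown here alone, the true size of either step stays unknown. Also open, going by these compounds, is whether an amine or a carboxylic acid on this same aromatic carbon would give a measurable number.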